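A few compounds are considered here, and "the series" means these few. Any claim that something is new, unique, unknown or untested is made for them only; others in the source may bear on it.

The series rests on a shared core, seen in compound 1 `CCOC1=C(/C(C)=N/OCC(=O)Nc2ccccc2)N(C)S(=O)(=O)c2ccccc21`, compound 2 `CCOC1=C(/C(C)=N/OCC(=O)Nc2cccc(OC)c2)N(C)S(=O)(=O)c2ccccc21` and compound 3 `COc1cccc(NC(=O)CO/N=C(\C)C2=C(O)c3ccccc3S(=O)(=O)N2C)c1`. In a functional assay on THP-1 cells (Homo sapiens) for inhibition, read by ELISA, with stated times of 2 h and 48 h (a lower number here means a stronger inhibitor, a higher number a weaker inhibitor), compound 1 gives only a limit, > 20000 nM. In this assay compound 2 likewise gives a limit, > 20000 nM. Compound 3 also returns a limit in this assay, > 20000 nM. Compound 3 thus stands at the edge of what this assay can report, together with the other two, as the limit of > 20000 nM in this assay, at which 3 of the 3 values shown sit, shows. The two measured steps, a step that the two limits leave unreadable from compound 1 to compound 2 and a step that the two limits leave unreadable from compound 2 to compound 3, both run between limits and yield no readable size. Compound 4 `C/C(=N\OCC(=O)Nc1c(F)cccc1F)C1=C(O)c2ccccc2S(=O)(=O)N1C` differs from compound 3 by 2,6-difluorophenyl in place of 3-methoxyphenyl on an amide-type nitrogen. Among the measured compounds shown here, no measured step with a readable size touches the group on the amide-type nitrogen, so neither step offers a basis for a direction in this assay. The expected step that the limit leaves unreadable from compound 3 to compound 4 is taken as no larger than the scatter, with a fair chance that compound 4 again returns a limit. Compound 4 is accordingly estimated to give about 30000 nM in this assay, between 10000 nM and 100000 nM.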

Compound 4, half-maximal inhibitory concentration: > 20000 nM
Compound 4: a limit, no number; the forecaster's own chance of this, stated with the estimate: 75%; the middle value lies beyond the limit too.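

Compound 4 returns only a limit in this assay, as compound 3 does, so no size can be read for the change from compound 3 to compound 4: the limit of > 20000 nM in this assay, at which 4 of the 4 values shown sit.

The compounds shown leave open whether any of these changes alters inhibition at all.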